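The source may report more compounds than this note shows. Statements on the series, on what has been measured and on what is new or still open speak of the compounds shown alone.

Measured in a functional assay on HL-60 cells (Homo sapiens) for antiproliferative activity, read by MTT assay, with a stated time of 72 h; a higher number here means a weaker inhibitor, a lower number a stronger inhibitor:
- compound 1 `CCn1cc(C(=O)O)c(=O)c2cc(F)c(N3CCN(C(=N)NS(=O)(=O)c4ccc(C(F)(F)F)cc4)CC3)cc21`: 43 nM
- compound 2 `N=C(NS(=O)(=O)c1ccccc1)N1CCN(c2cc3c(cc2F)c(=O)c(C(=O)O)cn3C2CC2)CC1`: 43 nM

Compound 2, at 43 nM, stands level with compound 1, at 43 nM. The two read the same at the digits given, and any true gap between them would be hidden within the usual scatter of repeated measurements.

The next compound to be tested is compound 3 `Cc1ccc(S(=O)(=O)NC(=N)N2CCN(c3cc4c(cc3F)c(=O)c(C(=O)O)cn4C3CC3)CC2)cc1`. It is built from compound 2 by one change: methyl in place of hydrogen on an aromatic carbon. In words, a methyl takes the place of a hydrogen on an aromatic carbon, para to a large group, turning the phenyl into a 4-methylphenyl.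

Among the compounds with values here, no measured pair here differs in only one place, so the data offer no direct guide to the size of such a change in this assay. The expectation therefore starts from compound 2 at 43 nM and predicts no shift beyond the scatter, in either direction. The expected change is a 1.0-fold higher number from compound 2 to compound 3 (0.02 log units; within the scatter). For compound 3 the estimated value is 45 nM, with an expected range from 16 nM to 125 nM.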

Compound 3, half-maximal inhibitory concentration: 43 nM
Beside the measured number, compound 3's estimate is 1.0-fold (0.02 log units) above it; the range from low to high includes it.
By their numbers in this assay, from the lowest: compounds 1, 2 and 3 (each within the scatter of the next).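

Within the data shown here, this pair is the first to differ in one place only, so it gives the first direct reading of a change on this aromatic ring. In this assay, the step from phenyl to 4-methylphenyl, with the methyl para to a large group, reads no change at the digits printed from compound 2 to compound 3 (within the scatter) and so shows that a hydrogen at this carbon can give way to a methyl without the number moving beyond the scatter. No other measurement bears on this result, so the data offer no explanation for it.

A single methyl cannot show whether the same carbon would tolerate other groups, such as a methoxy, a chlorine, an amine or a carboxylic acid, or whether a longer chain would leave the number just as still. Compound 1 carries a trifluoromethyl on the same ring but differs from compound 3 in more than one place, so that pair cannot show how a trifluoromethyl and a methyl compare at this position.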